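Amide variation in a CDK8/Cyclin C inhibitor series

This account rests on a few compounds, and the source may have more. Where it says the series, first, only, none or still open, it means among the compounds named here.

Measured so far:
compound 1, `NC(=O)/C=C/c1ccncc1-c1ccc2ccccc2c1`: 10.5 nM
compound 2, `CC(C)[C@@H](NC(=O)/C=C/c1ccncc1-c1ccc2ccccc2c1)C(=O)O`: "not determined" (no result reported)

Compound 1 gives 10.5 nM in an assay on a protein complex for inhibition of CDK8/Cyclin C (Homo sapiens), with a stated time of 1 h; on this read-out lower numbers stand for stronger inhibition and higher numbers for weaker inhibition. Compound 2 has no single number in this assay; where it stands relative to compound 1 is therefore unknown, and no comparison between the two can be drawn.

Compound 3 `COC1CN(C(=O)/C=C/c2ccncc2-c2ccc3ccccc3c2)C1` differs from compound 2 by 3-methoxyazetidin-1-yl in place of (1-carboxy-2-methylpropyl)amino on a carbonyl carbon. For the measured compounds named here, no step between two measured compounds is available in this set, so the size of the change from compound 2 to compound 3 cannot be read off; the working expectation in this assay is a modest step, if any beyond the usual scatter, more likely toward weaker than toward stronger inhibition. Because compound 1 gives 10.5 nM, compound 3 is expected to land near 25 nM, within a range of 6 nM to 120 nM.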

Compound 3, half-maximal inhibitory concentration: 42.8 nM
Compound 3: middle estimate off by 1.7-fold (0.23 log units), on the low side; the range from low to high includes it.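

In this assay, the carbonyl carbon accepts a cyclic substituent with inhibition retained: 3-methoxyazetidin-1-yl in place of amino gives a 4.1-fold higher number from compound 1 to compound 3 (0.61 log units; beyond the scatter), with compound 3 at 42.8 nM. This is a modest loss beyond the usual scatter, so the simple amino group remains the better of the two groups with a number at this position. Steps involving compound 2 cannot be read, as it has no single number, and no supporting data bear on the reason for the change seen with compound 3.

For the compounds shown here, the single step changes the ring, the methoxy group and the amide hydrogen together, so their separate contributions stay unresolved. A methylamino group, an unsubstituted azetidin-1-yl group or a 3-hydroxyazetidin-1-yl group would help separate them.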